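A few compounds are considered here, and "the series" means these few. Any claim that something is new, unique, unknown or untested is made for them only; others in the source may bear on it.

Compound 3, `Oc1cccc(-c2cc(-c3ccccn3)cc(-c3cccc(O)c3)n2)c1`, gives 3510 nM in a functional assay on HCT-15 cells (Homo sapiens) for cytotoxicity, read by CCK-8 assay; on this read-out lower numbers stand for stronger inhibition and higher numbers for weaker inhibition. Among the two plain numbers measured it is the higher one; the nearer neighbour is compound 1, `Oc1ccc(-c2cc(-c3ccoc3)cc(-c3cccc(O)c3)n2)cc1`, which in this assay gives 930 nM. Compound 2, `Oc1cccc(-c2cc(-c3ccccn3)cc(-c3ccccc3O)n2)c1`, reaches only a limit of this assay, > 50000 nM. That is the limit of > 50000 nM in this assay, at which 1 of the 3 values shown sits.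

For the measured compounds named here, the one step measured between compounds differing in a single place is the move of the hydroxyl on the phenyl next to the ring nitrogen: an at least 14-fold lower number from compound 2 to compound 3 (1.15 log units; beyond the scatter). The step to compound 4, `Oc1ccc(-c2cc(-c3ccccn3)cc(-c3cccc(O)c3)n2)cc1`, concerns the same phenyl, with 4-hydroxyphenyl in place of 3-hydroxyphenyl on an aromatic carbon. The earlier step shows that the position of this hydroxyl can move the number a great deal. Compound 1 also carries a 4-hydroxyphenyl and shows a lower number than compound 3, but it differs from compound 3 in a second place as well, so its value only hints at the direction. Compound 4 is therefore expected to give 1800 nM, within 500 nM to 6000 nM, an expected step of a 2.0-fold lower number from compound 3 to compound 4 (0.29 log units; within the scatter).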

Compound 4, half-maximal inhibitory concentration: > 50000 nM
Compound 4 ended at the assay's limit (the forecaster's own chance of this, stated with the estimate: 5%); middle value at least 27-fold (1.44 log units) away from the limit.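

In this assay, the hydroxyl on this phenyl turns out to be sensitive in both directions, with an at least 14-fold higher number from compound 3 to compound 4 (1.15 log units; beyond the scatter): with pyridin-2-yl in the molecule, only the 3-hydroxyphenyl among the three hydroxyl placements shown gives a plain number. The 4-hydroxyphenyl does not end at the limit by itself, however, as pyridin-2-yl in place of furan-3-yl brings an at least 53-fold higher number from compound 1 to compound 4 (1.73 log units; beyond the scatter). Compound 2 and compound 4 both stand at a limit rather than a number, so the step between them cannot be read: the limit of > 50000 nM in this assay, at which 2 of the 4 values shown sit.

From the compounds shown here alone, it remains open whether a methoxy or an amine in place of the hydroxyl on this phenyl would keep a plain number like that of compound 3, 3510 nM. Also open, going by these compounds, is how other hydroxyl placements on this phenyl behave together with furan-3-yl.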